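The source may report more compounds than this note shows. Statements on the series, on what has been measured and on what is new or still open speak of the compounds shown alone.

In a functional assay on a cell-free system (plasma) with sterol O-acyltransferase, Soat (Rattus norvegicus) as the target (on this read-out lower numbers stand for an effect already at smaller amounts and higher numbers for an effect only at larger amounts of compound), compound 2 `CSc1cc(C)nc(SC)c1NC(=O)N(Cc1ccccc1)Cc1cccc(-c2cc[nH]n2)c1` gives 0.046 mg/kg, the lower of the two values read as numbers. Compound 1 `O=C(Nc1c(F)cc(F)cc1F)N(Cc1ccccc1)Cc1cccc(-c2cc[nH]n2)c1` gives 0.096 mg/kg; the step of a 2.1-fold lower number from compound 1 to compound 2 (0.32 log units; beyond the scatter) replaces the aryl on the urea nitrogen and leaves untouched the group that compound 4 changes. For compound 3 `CSc1cc(C)nc(SC)c1NC(=O)N(Cc1ccccc1)Cc1ccc(-c2cc[nH]n2)cc1` this assay reports only a limit, < 0.32 mg/kg. The step that the limit leaves unreadable from compound 2 to compound 3 therefore cannot be sized, owing to the limit of < 0.32 mg/kg in this assay, at which 1 of the 3 values shown sits. Compound 4 `CSc1cc(C)nc(SC)c1NC(=O)N(Cc1ccccc1)Cc1cccc(-c2ccnn2C)c1` differs from compound 2 by 1-methyl-1H-pyrazol-5-yl in place of 1H-pyrazol-3-yl on an aromatic carbon. Going by the values given here, no measured step bears on this change, so its direction is open; for compound 4 the expected step is a 2.2-fold higher number from compound 2 to compound 4 (0.34 log units; beyond the scatter), set close to no change and with a wide range. Compound 4 is estimated at 0.1 mg/kg in this assay, between 0.03 mg/kg and 0.4 mg/kg.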

Compound 4, dose for half-maximal effect: < 1 mg/kg
Compound 4: no number, only a limit; the forecaster's own chance of this, stated with the estimate: 10%; the middle value is on the limit's open side.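

No step from compound 2 to compound 4 can be read, because compound 4 is reported only as a limit: the limit of < 1 mg/kg in this assay, at which 1 of the 4 values shown sits.

The compounds shown leave open whether 1-methyl-1H-pyrazol-5-yl in place of 1H-pyrazol-3-yl raises or lowers the number in this assay.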